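This account rests on a few compounds, and the source may have more. Where it says the series, first, only, none or still open, it means among the compounds named here.

In a functional assay on Right cardiac atrium for agonist activity at histamine H2 receptor (Cavia porcellus), with a stated time of 30 min, in the presence of a further agent that is not named here (a lower number here means a smaller maximal response, a higher number a larger maximal response), compound 3 `Cc1nc(N)sc1CCCN/C(N)=N/C(=O)N[C@@H](C)c1ccccc1` gives 1.08, the highest of the three numbers recorded. Compound 2 `Cc1nc(N)sc1CCCN/C(N)=N/C(=O)NC(C)c1ccc(Br)cc1` gives 0.87, which lies beyond the scatter below it, and compound 1 `Cc1nc(N)sc1CCCN/C(N)=N/C(=S)NC(c1ccccc1)c1ccccc1` gives 0.67, lower still. Compound 4 `Cc1nc(N)sc1CCCN/C(N)=N/C(=O)NC(C)c1cccs1` has not yet been measured in this assay. It differs from compound 3 in one place: 1-(thiophen-2-yl)ethyl in place of 1-phenylethyl on an amide-type nitrogen. Within the data shown here, no measured pair shows this change, so only the three values recorded can guide the expectation. Compound 2, which carries a different group on the amide-type nitrogen, gives 0.87, so some loss seems plausible. The step a number 0.13 lower from compound 3 to compound 4 (beyond the scatter) is expected to be a modest fall, possibly no larger than the scatter. Compound 4 is expected to give 0.95, between 0.75 and 1.1.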

Compound 4, intrinsic activity: the largest response reached, as a fraction of the reference agonist's: 0.88
Compound 4: middle estimate off by 0.070, on the high side, within the range that was stated.
By their numbers in this assay, from the lowest: compound 1; then compounds 2 and 4 (each within the scatter of the next); then compound 3.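

On this amide-type nitrogen, 1-(thiophen-2-yl)ethyl in place of 1-phenylethyl lowers the maximal response in this assay (a number 0.20 lower from compound 3 to compound 4 (beyond the scatter)). Thiophen-2-yl in place of 4-bromophenyl on the saturated chain carbon gives no distinguishable change (a number 0.010 higher from compound 2 to compound 4 (within the scatter)). The 1-phenylethyl group of compound 3 has a defined stereocentre and the entering group none, so the first step does not separate the ring change from the stereochemistry.

Going by these compounds, whether a pyridine ring or a cyclohexyl group would retain the response stays open. Nothing shown here accounts for the fall.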